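The source may report more compounds than this note shows. Statements on the series, on what has been measured and on what is new or still open speak of the compounds shown alone.

Measured so far:
compound 1 `CC(C)C(/N=C(\NC#N)Nc1cccnc1)C(C)C`, 5 mg/kg;
compound 2 `CC(C)CC(C)/N=C(\NC#N)Nc1ccncc1`, 35 mg/kg;
compound 3 `CCC(/N=C(\NC#N)Nc1ccncc1)C(C)C`, 5 mg/kg.

These values come from a functional assay on the whole organism (blood, strain Wistar-Okamoto) with Rattus norvegicus as the target, with a stated time of 5 days; a higher number here means that more compound is needed for the effect, a lower number that less compound is needed. Compound 3 sits level with compound 1 at the digits shown, and the step of a 7.0-fold lower number from compound 2 to compound 3 (0.85 log units; beyond the scatter) sets it apart from compound 2. Compound 4 `CC(C)C(/N=C(\NC#N)Nc1ccncc1)C(C)C` is the next one to be measured. It differs from compound 3 by methyl in place of hydrogen on a saturated chain carbon bound to two saturated chain carbons. Among the measured compounds shown here, the only measured step on this part of the molecule is the branching change from compound 2 to compound 3, and compound 1, which already carries this group on its own core, gives a value level with compound 3. A step of about no change at the digits printed from compound 3 to compound 4 (within the scatter) is therefore expected, that is none beyond the scatter. Compound 4 is estimated at 5 mg/kg, with a range from 2.5 mg/kg to 10 mg/kg.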

Compound 4, minimum effective dose: 8 mg/kg
Compound 4: middle estimate off by 1.6-fold (0.20 log units), on the low side; measured number inside the range.
By their numbers in this assay, from the lowest: compounds 1, 3 and 4 (each within the scatter of the next); then compound 2.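

In this assay, methyl in place of hydrogen on a saturated chain carbon bound to two saturated chain carbons, which turns ethyl into isopropyl, gives a 1.6-fold higher number from compound 3 to compound 4 (0.20 log units; within the scatter) and so leaves the number unchanged within the scatter. Pyridin-4-yl in place of pyridin-3-yl on an amine nitrogen gives a 1.6-fold higher number from compound 1 to compound 4 (0.20 log units; within the scatter) and likewise shows no readable change. Nothing measured here offers a reason for either result. Still open, from the compounds shown here alone, is whether a longer chain, a cyclohexyl group or an added amine at this carbon would keep the number in this range.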